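This account rests on a few compounds, and the source may have more. Where it says the series, first, only, none or still open, it means among the compounds named here.

Compound 1 `ClCc1cccc(Cn2cnc3ncnc(Cl)c32)c1` has in a functional assay on DU-145 cells (Homo sapiens) for cytotoxicity, read by sulforhodamine B assay, with a stated time of 48 h (a higher number here means that more compound is tolerated, a lower number that less compound is tolerated), no result, recorded as "not determined" (no result reported); where it stands on this read-out is open. Within the data shown here, the one number in hand comes from compound 2 `ClCc1cccc(Cn2cnc3c(Cl)nc(Cl)nc32)c1`, which in this assay gives 5620 nM. Compound 3 `ClCc1cccc(Cn2cnc3nc(Cl)nc(Cl)c32)c1` differs from compound 1 by chloro in place of hydrogen on an aromatic carbon. Among the measured compounds shown here, no measured step exists on this core, so the size of the move in this assay is unknown; the expectation is for a shift no larger than the usual scatter from what compound 2 shows, in no set direction. Compound 3 is estimated at 5000 nM, within 1500 nM to 20000 nM.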

Compound 3, concentration lethal to 50% of the cells: 520 nM
Compound 3: middle estimate off by 9.6-fold (0.98 log units), on the high side, and the stated range ends above it.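

No step can be read between compound 1 and compound 3 in this assay. The compounds shown leave open what the added chloro does to this read-out on the shared core, and nothing at hand bears on the result of compound 3.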